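The compounds below may be only part of what the source reports. "The series", "measured", "known", "first", "only" and "open" are said of these compounds alone.

Of the compounds shown here, three built on the same core have so far been tested in an assay on membranes from striatum (strain Sprague-Dawley) for displacement of a labelled ligand from sodium-dependent dopamine transporter (Rattus norvegicus), read by scintillation counting, with a stated time of 120 min; on this read-out lower numbers stand for stronger inhibition and higher numbers for weaker inhibition. Compound 1 `Fc1ccc(C(SCCNC2CCN(Cc3ccc(C(F)(F)F)cc3)CC2)c2ccc(F)cc2)cc1` gives 190 nM. Compound 2 `OC(Cc1ccccc1)CN1CCC(NCCSC(c2ccc(F)cc2)c2ccc(F)cc2)CC1` gives 31.4 nM. Compound 3 `O=C(c1cc2ccccc2[nH]1)N1CCC(NCCSC(c2ccc(F)cc2)c2ccc(F)cc2)CC1` gives 177 nM, the second highest of the three numbers; its result and that of compound 1 fall within the scatter of one another, as a 1.1-fold lower number from compound 1 to compound 3 (0.03 log units; within the scatter) shows, while a 5.6-fold higher number from compound 2 to compound 3 (0.75 log units; beyond the scatter) separates it clearly from compound 2. Compound 4 `CC(C)(C)C(=O)N1CCC(NCCSC(c2ccc(F)cc2)c2ccc(F)cc2)CC1` has not yet been measured. It differs from compound 3 by tert-butyl in place of 1H-indol-2-yl on a carbonyl carbon. Among the compounds with values here, no measured step changes the group on the carbonyl carbon itself. The two steps that touch the amine nitrogen in the ring, a 1.1-fold lower number from compound 1 to compound 3 (0.03 log units; within the scatter) and a 5.6-fold higher number from compound 2 to compound 3 (0.75 log units; beyond the scatter), show that exchanging the whole group there can leave the number unchanged or shift it modestly. Nothing in these data tells an aromatic from a saturated group at this place. A step within or only just beyond the scatter, leaning toward a higher number, is therefore expected, and the estimate for compound 4 is 320 nM, with a range from 110 nM to 950 nM. For compound 4 this expectation amounts to a 1.8-fold higher number from compound 3 to compound 4 (0.26 log units; within the scatter).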

Compound 4, inhibition constant: 352 nM
Compound 4: middle estimate off by 1.1-fold (0.04 log units), on the low side; measured number inside the range.
By their numbers in this assay, from the lowest: compound 2; then compounds 3, 1 and 4 (each within the scatter of the next).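

Within the data shown here, this is the first measured change of the group on the carbonyl carbon itself, and in this assay exchanging 1H-indol-2-yl, with its two aromatic rings and one hydrogen-bond donor, for tert-butyl, with no ring and no donor, stays within the scatter (a 2.0-fold higher number from compound 3 to compound 4 (0.30 log units; within the scatter)). Across the amine nitrogen in the ring, compound 4 also stays within the scatter of the benzyl-bearing compound (a 1.9-fold higher number from compound 1 to compound 4 (0.27 log units; within the scatter)), yet it stands far from the hydroxy-bearing compound (an 11-fold higher number from compound 2 to compound 4 (1.05 log units; beyond the scatter)), so compound 2 remains the only one set apart from the other three. No evidence is available that would explain these numbers.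

Still open, on these data alone, is whether a methyl group or an amine on the carbonyl carbon would stay within this same band. The compounds shown also cannot separate the role of the carbonyl from that of the hydroxyl, which a plain 3-phenylpropyl chain on the ring nitrogen would address.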